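Replacing a chain-end group on a pyridazinone series

The compounds below may be only part of what the source reports. "The series", "measured", "known", "first", "only" and "open" are said of these compounds alone.

Measured compounds:
- compound 1, `O=c1ccc(-c2ccccc2)nn1CCCCNC(=S)Nc1ccc(Cl)cc1`: 43.2%
- compound 2, `C/N=C(/NC#N)NCCCCn1nc(N(C)C)ccc1=O`: 26.3%
- compound 3, `N#CNC(=N)NCCCCCn1nc(-c2ccccc2)ccc1=O`: 31%

All three were tested in a functional assay on the whole organism with Rattus norvegicus as the target, at a dose of 100 mg/kg; on this read-out higher numbers stand for more inhibition at the one dose given (going by the name of the read-out) and lower numbers for less inhibition. Compound 3 gives 31% in this assay, the second highest of the three numbers. Its nearest neighbour is compound 2, which gives 26.3%; the gap between these two falls within the scatter, so no order can be read from it. Compound 1 gives 43.2%, and its gap to compound 3 lies beyond the scatter.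

Compound 4, `CN(C)/C(=N/CCCCn1nc(-c2ccccc2)ccc1=O)NC#N`, has not yet been measured. It differs from compound 3 in one place: a group of 8 heavy atoms (4 carbon, 4 nitrogen; no ring) in place of a group of 7 heavy atoms (3 carbon, 4 nitrogen; no ring), on a saturated chain carbon, four bonds along the chain from an aromatic nitrogen. Within the data shown here, no measured pair in this set shows this kind of exchange, so there is no step to lean on. Since compound 2 and compound 3 carry different chain-end groups yet sit within the scatter of each other, the expectation for compound 4 is a step from compound 3 of no size beyond the scatter, a number 1 percentage points lower from compound 3 to compound 4 (within the scatter). For compound 4 the estimated value in this assay is 30%, with a range from 15% to 45%.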

Compound 4, a percentage reported as inhibition, in the whole organism at one dose (the size of the read-out at that dose, not a potency): 80.7%
The estimate for compound 4 lay 50.7 percentage points below the measured number; the whole stated range lies below it.
By their numbers in this assay, from the lowest: compounds 2 and 3 (each within the scatter of the next); then compound 1; then compound 4.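

In this assay, the group at this chain position turns out to matter a great deal: the group of 8 heavy atoms in place of the group of 7 heavy atoms gives a number 49.7 percentage points higher from compound 3 to compound 4 (beyond the scatter), so one exchange on a saturated chain carbon, four bonds along the chain from an aromatic nitrogen, can move the number far beyond the scatter. Counted across the exchange, hydrogen-bond acceptors stay at 2, while hydrogen-bond donors go from 3 to 1. Nothing given here explains why the number moved so far.

This single pair alters the chain and its end group together, so it does not show which part of the exchange carries the step. Also open, going by these compounds, is how the number would respond if a pyrrolidine ring took the place of the two methyl groups on that nitrogen.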